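Adding one side chain to compound 1

The source may report more compounds than this note shows. Statements on the series, on what has been measured and on what is new or still open speak of the compounds shown alone.

In a functional assay on PC-3 cells (Homo sapiens) for cytotoxicity, read by MTT assay, with a stated time of 24 h (on this read-out higher numbers stand for weaker inhibition and lower numbers for stronger inhibition), compound 1 `COc1ccc2c(c1)cc(-c1cc(OC)c(OC)c(OC)c1)n2Cc1ccccc1` gives > 30000 nM as a limit of the assay, not a number. Compound 2 `COc1ccc2c(c1)c(Cc1ccc(OCc3ccccc3)cc1)c(-c1cc(OC)c(OC)c(OC)c1)n2Cc1ccc(OCc2ccccc2)cc1` gives > 30000 nM as its own limit. Compound 1 therefore stands at the limit of > 30000 nM in this assay, at which 2 of the 2 values shown sit, and has no exact number. Compound 3 `CCOCC(=O)Oc1ccc(Cn2c(-c3cc(OC)c(OC)c(OC)c3)cc3cc(OC)ccc32)cc1` carries ((ethoxymethyl)carbonyl)oxy in place of hydrogen on an aromatic carbon, para to a large group (((ethoxymethyl)carbonyl)oxy in place of hydrogen on an aromatic carbon). Among the compounds with values here, no measured step shows what such a change does, so the expected step of an at least 1.5-fold lower number from compound 1 to compound 3 (0.17 log units; that floor lies within the scatter) is small, towards stronger inhibition in this assay and uncertain. For compound 3 the estimated value is 20000 nM within a range of 5000 nM to 40000 nM on this thin evidence.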

Compound 3, half-maximal inhibitory concentration: > 30000 nM
Compound 3: only a limit was reported; the forecaster's own chance of this, stated with the estimate: 55%; at least 1.5-fold (0.17 log units) between middle value and limit.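

Within the data shown here, no step from compound 1 to compound 3 can be read, since each compound stands at a limit of the assay and not at a number: the limit of > 30000 nM in this assay, at which 3 of the 3 values shown sit. On these data alone, how strongly these compounds inhibit, and whether ((ethoxymethyl)carbonyl)oxy changes that at all, stays open.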